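This account rests on a few compounds, and the source may have more. Where it says the series, first, only, none or still open, it means among the compounds named here.

Compound 1 `COc1ccc(-c2cnc3nc(N)nc(N4CCN(C(=O)Nc5cccc(C)c5)CC4)c3n2)cc1OC`, compound 2 `COc1ccc(-c2cnc3nc(N)nc(N4CCN(C(=O)Nc5ccc(C#N)cc5)CC4)c3n2)cc1OC` and compound 3 `COc1ccc(-c2cnc3nc(N)nc(N4CCN(Cc5ccccc5)CC4)c3n2)cc1OC` share one core and differ only in the group carried on the amine nitrogen of the six-membered non-aromatic ring. In a functional assay on cells (T-cell, Homo sapiens) for inhibition (a lower number here means a stronger inhibitor, a higher number a weaker inhibitor), compound 1 gives 7 nM, compound 2 gives 74 nM and compound 3 gives 900 nM. The step of an 11-fold higher number from compound 1 to compound 2 (1.02 log units; beyond the scatter) is large, and the two steps that arrive at compound 3, a 130-fold higher number from compound 1 to compound 3 (2.11 log units; beyond the scatter) and a 12-fold higher number from compound 2 to compound 3 (1.09 log units; beyond the scatter), are larger still. Compound 3 therefore stands highest of the three numbers in this assay, with compound 2 nearest to it and compound 1 furthest away.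

Compound 4 `COc1ccc(-c2cnc3nc(N)nc(N4CCN(c5ccccc5)CC4)c3n2)cc1OC` is reached from compound 3 by the change (phenyl in place of benzyl on an amine nitrogen in a ring). Among the compounds with values here, no measured step covers this change: both steps that lead to compound 3 exchange a carbamoyl group for benzyl, and neither compares a benzyl with a phenyl on the ring nitrogen. With no guidance from the measured steps, the step of a 1.3-fold lower number from compound 3 to compound 4 (0.11 log units; within the scatter) is expected to stay within the usual scatter, in no firm direction. Compound 4 is accordingly estimated at 700 nM in this assay, with a range from 200 nM to 2500 nM.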

Compound 4, half-maximal inhibitory concentration: 400 nM
The estimate for compound 4 lay 1.8-fold (0.24 log units) above the measured number; measured number inside the range.
By their numbers in this assay, from the lowest: compound 1; then compound 2; then compound 4; then compound 3.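

Phenyl in place of benzyl on the amine nitrogen in the ring gives, in this assay, a 2.3-fold lower number from compound 3 to compound 4 (0.35 log units; beyond the scatter): a modest step, but one that shows that these two groups without a carbamoyl link do not read alike at this position. Neither group comes close to the urea-type substituents, however, as phenyl in place of (4-cyanophenyl)carbamoyl gives a 5.4-fold higher number from compound 2 to compound 4 (0.73 log units; beyond the scatter) and phenyl in place of (3-methylphenyl)carbamoyl gives a 57-fold higher number from compound 1 to compound 4 (1.76 log units; beyond the scatter), so among these four compounds both carbamoyl compounds keep the lower numbers, with none going against this. Nothing available here accounts for the step from benzyl to phenyl or for the gap to the carbamoyl compounds.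

The compounds shown leave open whether the gap follows the carbamoyl unit itself or the aryl group it carries, which a 3-methylphenyl ring set directly on the ring nitrogen, or an acetyl group there, would help to separate. They also leave open how the number moves with a longer chain, such as 2-phenylethyl, on the same nitrogen.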